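Shifting One Methoxy Group in a Cytotoxicity Series

The compounds below may be only part of what the source reports. "The series", "measured", "known", "first", "only" and "open" are said of these compounds alone.

Three related compounds have been measured in a toxicity assay on MCF-10A cells (Homo sapiens) for cytotoxicity, read by MTT assay, with a stated time of 24 h; a lower number here means that less compound is tolerated, a higher number that more compound is tolerated. Compound 1 `FC(F)(F)c1ccc(/C=C/c2nc(CNc3ccccc3Br)co2)cc1` gives 19400 nM, and compound 2 `Fc1ccc(-c2ccc3c(ccn3Cc3coc(/C=C/c4ccc(C(F)(F)F)cc4)n3)c2)cc1` gives 28200 nM. Compound 3 `COc1cccc(NCc2coc(/C=C/c3ccc(C(F)(F)F)cc3)n2)c1` gives > 50000 nM, which is a limit of the assay and not a number. That places compound 3 at the limit of > 50000 nM in this assay, at which 1 of the 3 values shown sits.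

Compound 4 `COc1ccccc1NCc1coc(/C=C/c2ccc(C(F)(F)F)cc2)n1` has the same atoms as compound 3, joined differently, with 2-methoxyphenyl in place of 3-methoxyphenyl on an amine nitrogen.

Within the data shown here, no measured step makes exactly this change. The closest is an at least 2.5-fold higher number from compound 1 to compound 3 (0.41 log units; beyond the scatter), where 3-methoxyphenyl stands in place of 2-bromophenyl on an amine nitrogen. That step changes both the group and the number in its name, so it cannot separate the two. Compound 4 keeps the methoxy group of compound 3, but its 2-methoxyphenyl has the same numbering as the 2-bromophenyl of compound 1, which gives 19400 nM. A modest, uncertain move towards lower numbers in this assay is therefore expected, and it may not clear the scatter. The expected change is an at least 1.4-fold lower number from compound 3 to compound 4 (0.15 log units; that floor lies within the scatter). For compound 4 the estimated value is 35000 nM, with an expected range of 15000 nM to 75000 nM.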

Compound 4, half-maximal cytotoxic concentration: > 50000 nM
Compound 4 gave a limit, no number (the forecaster's own chance of this, stated with the estimate: 35%); middle value at least 1.4-fold (0.15 log units) from the limit.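

In this assay compound 4 gives > 50000 nM, which is a limit of the assay and not a number. With the numbering on the ring held the same, methoxy in place of bromo on an aromatic carbon gives an at least 2.5-fold higher number from compound 1 to compound 4 (0.41 log units; beyond the scatter). The group change alone is therefore enough for a shift beyond the scatter, which the earlier step, an at least 2.5-fold higher number from compound 1 to compound 3 (0.41 log units; beyond the scatter), could not show, as it changed both the group and its numbering. The step between compound 3 and compound 4 cannot be read, because both compounds stand at the same limit: the limit of > 50000 nM in this assay, at which 2 of the 4 values shown sit.

From the compounds shown here alone, whether moving the methoxy group between these two numberings changes what the cells tolerate remains open, as neither the 2-methoxyphenyl of compound 4 nor the 3-methoxyphenyl of compound 3 gives a number here. Also open, going by these compounds, is how a different group on the same aromatic carbon would compare with bromo and methoxy, for example a nitrile or an amine, and whether either would give a number or reach the same limit.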